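The compounds below may be only part of what the source reports. "The series", "measured", "known", "first", "only" and "open" are said of these compounds alone.

Measured in an assay on isolated protein for inhibition of protein kinase C theta type (Homo sapiens), read by TR-FRET, with a stated time of 2 h; on this read-out higher numbers stand for weaker inhibition and lower numbers for stronger inhibition:
compound 1 `N#Cc1cnc(NCc2cnccc2C(F)(F)F)cc1NC[C@H]1C[C@H](O)C1` gives 700 nM;
compound 2 `N#Cc1cnc(NCc2cnccc2C(F)(F)F)cc1N[C@H]1CC[C@@H](C(N)=O)CC1` gives 7 nM;
compound 3 `CC1(C)C[C@@H](Nc2cc(NCc3cnccc3C(F)(F)F)ncc2C#N)CC[C@@H]1O` gives 120 nM.

Compound 3 stands second highest of the three numbers, nearer to compound 1 than to compound 2. Compound 4 `CC1(C)[C@H](Nc2cc(NCc3cnccc3C(F)(F)F)ncc2C#N)C[C@H]1C(N)=O` is not yet measured; the change from compound 3 is 3-carbamoyl-2,2-dimethylcyclobutyl in place of 4-hydroxy-3,3-dimethylcyclohexyl on a nitrogen on an aromatic ring. Among the compounds with values here, two measured steps bear on it. The carbamoyl group has been strongly favoured: a 17-fold higher number from compound 2 to compound 3 (1.23 log units; beyond the scatter) and a 100-fold lower number from compound 1 to compound 2 (2.00 log units; beyond the scatter). A four-membered ring appears only in compound 1, the weakest number shown, so a full return to the level of compound 2 is not assumed. A large fall in this assay is nevertheless expected: a 4.0-fold lower number from compound 3 to compound 4 (0.60 log units; beyond the scatter). Compound 4 is estimated at 30 nM, with a range of 8 nM to 120 nM.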

Compound 4, half-maximal inhibitory concentration: 140 nM
Estimate against measurement, compound 4: 4.7-fold (0.67 log units) below, outside the stated range (above it).
By their numbers in this assay, from the lowest: compound 2; then compounds 3 and 4 (each within the scatter of the next); then compound 1.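

In this assay the carbamoyl group alone does not hold the level of compound 2: 3-carbamoyl-2,2-dimethylcyclobutyl in place of 4-carbamoylcyclohexyl gives a clear loss (a 20-fold higher number from compound 2 to compound 4 (1.30 log units; beyond the scatter)). At this nitrogen the amide-bearing cyclobutyl reads no differently from 4-hydroxy-3,3-dimethylcyclohexyl (a 1.2-fold higher number from compound 3 to compound 4 (0.07 log units; within the scatter)), yet it still improves on (3-hydroxycyclobutyl)methyl (a 5.0-fold lower number from compound 1 to compound 4 (0.70 log units; beyond the scatter)), so the ring and its substituent have to be read together. No measured evidence accounts for this.

Still open, as far as these compounds go, is whether a carboxylic acid in place of the carbamoyl group on the cyclohexyl ring keeps the level of compound 2. Also open, from the compounds shown here alone, is whether the cyclobutyl amide without its two methyl groups reads differently from compound 4.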